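Working notes on three measured compounds and a fourth

The source may report more compounds than this note shows. Statements on the series, on what has been measured and on what is new or still open speak of the compounds shown alone.

Measured compounds and values:
compound 1 `CC(C)(C)c1ccc(-n2nc(-c3ccc(C(F)(F)F)cc3O)nc2-c2ccccc2O)cc1`: 81.1%
compound 2 `Oc1cc(C(F)(F)F)ccc1-c1nc(-c2ccccc2O)n(-c2ccc(I)cc2)n1`: 105%
compound 3 `Oc1cc(C(F)(F)F)ccc1-c1nc(-c2ccccc2O)n(-c2cccc(F)c2)n1`: 98.3%

All three share one core and differ only in the ring on the aromatic nitrogen. In a functional assay on PC-12 cells (Rattus norvegicus) for cytotoxicity, read by MTT assay, with stated times of 2 h and 24 h, tested at 10 uM (on this read-out higher numbers stand for a stronger effect at the one concentration tested and lower numbers for a weaker effect), compound 3 stands second highest of the three numbers. Toward compound 2 the gap is a number 6.7 percentage points lower from compound 2 to compound 3 (within the scatter), so the two are not separable on this read-out. Toward compound 1 the step is a number 17.2 percentage points higher from compound 1 to compound 3 (beyond the scatter), and compound 1 to compound 2 is a number 23.9 percentage points higher from compound 1 to compound 2 (beyond the scatter), so both exchanges away from compound 1 raise the number by a modest amount.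

Compound 4 `COc1cccc(-n2nc(-c3ccc(C(F)(F)F)cc3O)nc2-c2ccccc2O)c1` keeps the core and changes the same ring: methoxy in place of fluoro on an aromatic carbon

Within the data shown here, no measured step swaps fluoro for methoxy; the only steps that bear on it are the three exchanges on this ring, which moved the number by modest amounts at most and, between compound 2 and compound 3, not beyond the scatter. The step of a number 2.3 percentage points lower from compound 3 to compound 4 (within the scatter) is therefore expected to stay within the scatter, with no preferred direction. Compound 4 is estimated at 96% in this assay, with a range of 80% to 110%.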

Compound 4, a percentage reported as activity, at one concentration (the size of the read-out at that concentration, not a potency): 106%
The estimate for compound 4 lay 10 percentage points below the measured number; the measured number falls inside the stated range.
By their numbers in this assay, from the lowest: compound 1; then compounds 3, 2 and 4 (each within the scatter of the next).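

In this assay methoxy in place of fluoro gives a number 7.7 percentage points higher from compound 3 to compound 4 (within the scatter) and the exchange of 4-iodophenyl for 3-methoxyphenyl gives a number 1 percentage points higher from compound 2 to compound 4 (within the scatter) so this read-out does not separate 3-methoxyphenyl, 3-fluorophenyl and 4-iodophenyl on the aromatic nitrogen, even though methoxy brings oxygen where fluoro had none. The exchange of 4-(tert-butyl)phenyl for 3-methoxyphenyl gives a number 24.9 percentage points higher from compound 1 to compound 4 (beyond the scatter) and is the third modest step away from compound 1, which now stands apart from three neighbours carrying different groups, while compound 2, compound 3 and compound 4 form a single group on this read-out. Nothing at hand explains why compound 1 stands apart or why the other three do not separate.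

On these data alone, whether the lower number of compound 1 follows the tert-butyl group itself or its place on the ring remains open, since the step from compound 1 changes both group and place. Also open, as far as these compounds go, is whether an amine, a carboxylic acid or a longer chain such as butoxy on this ring would stay with compound 4 or move toward compound 1.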